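A few compounds are considered here, and "the series" means these few. Any claim that something is new, unique, unknown or untested is made for them only; others in the source may bear on it.

Three compounds have been measured in an ADME assay on the whole organism (Macaca fascicularis) for metabolic stability, read by LC-MS, using cassette dosing, at a dose of 1 mg/kg by the oral route; on this read-out higher numbers stand for a longer-lived compound and lower numbers for a shorter-lived compound:

Compound 1 `CCCCN(c1nc2c(C(=O)O)cccc2o1)[C@H](C)c1ccc(-c2ccccc2-c2nnn[nH]2)cc1` gives 3.7 h
Compound 2 `C[C@H](c1ccc(-c2ccccc2-c2nc(=O)o[nH]2)cc1)N(CC1CC1)c1nc2c(C(=O)O)cccc2o1` gives 2.6 h
Compound 3 `CCCCN(c1nc2c(C(=O)O)cccc2o1)[C@H](C)c1ccc(-c2cc(Cl)ccc2-c2nc(=O)o[nH]2)cc1` gives 2 h

On these numbers compound 1 stands at the top of the three, but its gap to compound 2 and its gap to compound 3 both fall within the usual scatter of this assay, so the three readings cannot be told apart with any confidence. Changes elsewhere in the molecule, at the chain on the nitrogen, at the ring that carries the acidic group and at that acidic group itself, have so far left the half-life in the same band.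

Compound 4 `CCCCN(c1nc2c(C(=O)NS(C)(=O)=O)cccc2o1)[C@H](C)c1ccc(-c2ccccc2-c2nnn[nH]2)cc1` has not yet been measured. It differs from compound 1 in one place: methanesulfonamido in place of hydroxy on a carbonyl carbon. No measured pair of compounds differs in this way, so there is no shown step to lean on, and the expectation rests only on how little the half-life has moved across the three measured compounds. In this assay the step is expected to be a 1.2-fold lower number from compound 1 to compound 4 (0.09 log units; within the scatter), small and without a clear direction, not beyond the scatter. For compound 4 the estimated half-life is 3 h, with a likely range from 1.2 h to 7.5 h.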

Compound 4, half-life: 2.7 h
Estimate against measurement, compound 4: 1.1-fold (0.05 log units) above; low and high end bracket the measured number.
By their numbers in this assay, from the lowest: compounds 3, 2, 4 and 1 (each within the scatter of the next).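

In this assay, among these compounds, methanesulfonamido in place of hydroxy on a carbonyl carbon gives a 1.4-fold lower number from compound 1 to compound 4 (0.14 log units; within the scatter), and this is the first comparison in the set in which only one place differs. It shows that this carbonyl carbon can carry a much larger group, with 5 heavy atoms entering where 1 heavy atom leaves, and the two half-lives still cannot be told apart. Nothing among the data shown explains this result or says what happens to these compounds in the animal.

From the compounds shown here alone, this is a single change on a single parent, so it remains open whether other groups on the same carbonyl carbon, such as a simple amino group giving a primary amide, a methoxy group giving a methyl ester or a longer benzenesulfonamido group, would also stay within the scatter. Going by these compounds, it also remains open whether the same swap behaves alike on compound 2 or compound 3, where a different ring stands in place of the tetrazole of compound 1 and other parts of the molecule differ as well.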